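The source may report more compounds than this note shows. Statements on the series, on what has been measured and on what is new or still open speak of the compounds shown alone.

Measured so far in an ADME assay on microsomes from liver (Homo sapiens) for metabolic stability, tested at 2.5 uM; on this read-out higher numbers stand for fast clearance and lower numbers for slow clearance:
compound 1 `O=S(=O)(c1ccc(F)c(Cl)c1)c1cnc2cc(F)ccc2c1-c1cccc(Cl)c1` gives 0.66 mL/min;
compound 2 `O=S(=O)(c1ccc(F)c(Cl)c1)c1cnc2cc(F)ccc2c1-c1ccccc1F` gives 1.07 mL/min.

For the measured compounds named here, compound 2 has the highest of the two numbers, but its only neighbour is compound 1, and the step of a 1.6-fold higher number from compound 1 to compound 2 (0.21 log units; within the scatter) lies within the scatter, so the two compounds cannot be told apart on this read-out.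

Compound 3 `COc1ccc(-c2c(S(=O)(=O)c3ccc(F)c(Cl)c3)cnc3cc(F)ccc23)cc1` is not yet measured in this assay. It differs from compound 2 in one place: 4-methoxyphenyl in place of 2-fluorophenyl on an aromatic carbon.

Going by the values given here, the one measured step, from compound 1 to compound 2, also exchanges the ring attached at that position, and it was within the scatter. Among the compounds with values here, nothing measured here shows that changing this ring moves the number beyond the scatter, and there is no measured compound carrying 4-methoxyphenyl to lean on. Compound 3 is therefore expected to lie close to compound 2, with a step of a 1.2-fold higher number from compound 2 to compound 3 (0.08 log units; within the scatter) that is not expected to exceed the scatter. The estimate for compound 3 in this assay is 1.3 mL/min, with a range from 0.6 mL/min to 2.8 mL/min.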

Compound 3, intrinsic clearance in a liver preparation (reported as CLH), per the amount of preparation that the assay uses: 1.08 mL/min
Compound 3: the middle estimate sits 1.2-fold (0.08 log units) above what was measured, within the range that was stated.
By their numbers in this assay, from the lowest: compounds 1, 2 and 3 (each within the scatter of the next).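

In this assay, 4-methoxyphenyl in place of 2-fluorophenyl gives a 1.0-fold higher number from compound 2 to compound 3 (0.00 log units; within the scatter), and 4-methoxyphenyl in place of 3-chlorophenyl gives a 1.6-fold higher number from compound 1 to compound 3 (0.21 log units; within the scatter). A third substituted phenyl group on this aromatic carbon, here the one with a hydrogen-bond acceptor and with oxygen in place of a halogen, therefore stays within the scatter of both earlier compounds, so the three exchanges at this position cannot be told apart on this read-out. Nothing available accounts for why these groups read alike.

As far as these compounds go, all three compounds carry a substituted phenyl group at this position, so it remains open whether an amine, a carboxylic acid or a longer chain there would move the number beyond the scatter. From the compounds shown here alone, whether changes elsewhere on the shared core would do so also remains open.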